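Replacing chloro with methyl in compound 1

This account rests on a few compounds, and the source may have more. Where it says the series, first, only, none or still open, it means among the compounds named here.

In a functional assay on HUVEC cells (Homo sapiens), read by BrdU incorporation, with a stated time of 72 h (on this read-out lower numbers stand for stronger inhibition and higher numbers for weaker inhibition), compound 1 `Cc1ccc2nc(Cl)c(/C=C/C(=O)c3ccc(Cl)s3)cc2c1` gives 59.4 nM and stands close to compound 3 `Cc1ccc2cc(/C=C/C(=O)c3ccc(Cl)s3)c(Cl)nc2c1` at 49.5 nM, the two lying within the scatter of each other. Compound 2 `Cc1ccc2cc(/C=C/C(=O)c3ccc(I)s3)c(Cl)nc2c1` gives 135 nM, a number higher than that of compound 1 by more than the scatter. Compound 4 `Cc1ccc2nc(Cl)c(/C=C/C(=O)c3ccc(C)s3)cc2c1` has not been measured. It departs from compound 1 by a single change (methyl in place of chloro on an aromatic carbon), in which 5-chlorothiophen-2-yl becomes 5-methylthiophen-2-yl. Among the measured compounds shown here, one measured step bears on this: chloro in place of iodo on an aromatic carbon gave a 2.7-fold lower number from compound 2 to compound 3 (0.44 log units; beyond the scatter), a modest move showing that a group swap of this kind can shift the number. For the measured compounds named here, no measured compound carries the methyl, so that step gives only a weak hint of direction. A small rise is expected, with the estimated step of a 1.5-fold higher number from compound 1 to compound 4 (0.18 log units; within the scatter) staying within the scatter. Compound 4 is therefore estimated at 90 nM, with an expected range from 35 nM to 230 nM in this assay.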

Compound 4, half-maximal inhibitory concentration: 128 nM
Beside the measured number, compound 4's estimate is 1.4-fold (0.15 log units) below it; the measured number falls inside the stated range.
By their numbers in this assay, from the lowest: compounds 3 and 1 (each within the scatter of the next); then compounds 4 and 2 (each within the scatter of the next).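

In this assay, methyl in place of chloro on this aromatic carbon next to the ring sulfur gives a 2.2-fold higher number from compound 1 to compound 4 (0.33 log units; beyond the scatter), so this position responds by more than the scatter to a change that leaves the halogens. Among the compounds shown here, the only earlier step here was between two halogens, a 2.7-fold lower number from compound 2 to compound 3 (0.44 log units; beyond the scatter), and chloro now carries the lower number in both pairs, although the two pairs do not share the same core. Nothing measured here gives a reason for the shift.

On these data alone, what an amine, a methoxy group or a longer chain such as propyl would give on this carbon remains open. Also open, as far as these compounds go, is whether methyl in place of chloro would give a similar step on the core of compound 3.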